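The source may hold more compounds than are shown below. What is called first, only, known or untested is meant among the compounds shown, and "the series" means these compounds.

Measured in a functional assay on MGC-803 cells (Homo sapiens) for antiproliferative activity, read by MTT assay, with a stated time of 48 h; on this read-out higher numbers stand for weaker inhibition and lower numbers for stronger inhibition:
- compound 1 `COc1ccc(CN(C(=O)CSc2nc3ccccc3s2)c2cc(OC)c(OC)c(OC)c2)cc1[N+](=O)[O-]`: 682 nM
- compound 2 `COc1ccc(CN(C(=O)CSc2nc3ccccc3s2)c2cc(OC)c(OC)c(OC)c2)cc1OC`: 34100 nM

Compound 2 has the higher number of the two, so it is the weaker inhibitor. Compound 3 `COc1cc(N(Cc2ccc(F)cc2)C(=O)CSc2nc3ccccc3s2)cc(OC)c1OC` carries 4-fluorobenzyl instead of its 3,4-dimethoxybenzyl: 4-fluorophenyl in place of 3,4-dimethoxyphenyl on a saturated chain carbon bound to an amide-type nitrogen. Going by the values given here, only one measured step bears on this: a 50-fold higher number from compound 1 to compound 2 (1.70 log units; beyond the scatter), a large step that put methoxy in place of nitro on this same benzyl group. The new benzyl carries neither nitro nor methoxy, so that step is only a rough guide. The expected change is a 5.7-fold lower number from compound 2 to compound 3 (0.75 log units; beyond the scatter), a lower number but a smaller step than the measured one. The estimate for compound 3 is 6000 nM, with an expected range of 1200 nM to 30000 nM.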

Compound 3, half-maximal inhibitory concentration: > 80000 nM
Compound 3 gave a limit, no number; the forecaster's own chance of this, stated with the estimate: 8%; middle value at least 13-fold (1.12 log units) away from the limit.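

In this assay, compound 3 gives > 80000 nM, which is a limit of the assay and not a number. Replacing 3,4-dimethoxybenzyl with 4-fluorobenzyl brings no recovery of activity: the change is an at least 2.3-fold higher number from compound 2 to compound 3 (0.37 log units; beyond the scatter), and the gap to the nitro compound is an at least 110-fold higher number from compound 1 to compound 3 (2.06 log units; beyond the scatter). Among these three compounds, only the 4-methoxy-3-nitrophenyl group of compound 1 gives strong inhibition, so losing the nitro group costs activity with either replacement tested here. The compounds shown leave open whether a benzyl group carrying nitro without methoxy keeps this strength, and whether an amine or a nitrile in place of nitro would do the same.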